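Amide-sulfonanilide pair: chloro to cyano swap, cytotoxicity

The source may hold more compounds than are shown below. What is called first, only, known or untested is meant among the compounds shown, and "the series" means these compounds.

Measured so far:
Compound 1 `CCS(=O)(=O)Nc1ccc(NC(=O)c2ccc(C#N)cc2)cc1OC` gives > 250000 nM in an ADME assay on HEK293 cells (Homo sapiens) for cytotoxicity, read by MTT assay, with a stated time of 48 h; a lower number here means a stronger inhibitor, a higher number a weaker inhibitor; this is a limit of the assay, not a number.
Compound 2 `COc1cc(NC(=O)c2ccc(Cl)cc2)ccc1NS(=O)(=O)C(F)(F)F` gives > 250000 nM in this assay ; this too is a limit.

Where compound 2 stands: only a limit is known for it, and the one further value shown is also a limit, so the two compounds cannot be ordered against each other. the limit of > 250000 nM in this assay, at which 2 of the 2 values shown sit, is the whole of the evidence, and no step between measured compounds that differ in one place is available.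

Compound 3 `COc1cc(NC(=O)c2ccc(C#N)cc2)ccc1NS(=O)(=O)C(F)(F)F` is next, to be measured in this assay. It differs from compound 2 by cyano in place of chloro on an aromatic carbon, in words cyano in place of chloro on an aromatic carbon. Going by the values given here, with no measured step of this kind, the expected size of the step is none beyond the scatter, and the reading is expected to stay at the limit.

Compound 3 is expected at 250000 nM, with a range from 120000 nM to 500000 nM. The step this estimate means, a number no higher from compound 2 to compound 3 (the limit leaves the size open), is expected to be no change beyond the scatter.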

Compound 3, half-maximal inhibitory concentration: > 250000 nM
Compound 3 ended at the assay's limit; the forecaster's own chance of this, stated with the estimate: 85%; the middle value lies on the limit itself.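

In this assay no step can be read among compound 1, compound 2 and compound 3, as all three stand at a limit of the assay: the limit of > 250000 nM in this assay, at which 3 of the 3 values shown sit.

The compounds shown leave open whether cyano in place of chloro, or trifluoromethyl in place of ethyl, alters cytotoxicity at all, and what number any of the three would give.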